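The source may hold more compounds than are shown below. What is called first, only, known or untested is meant among the compounds shown, and "the series" means these compounds.

Measured compounds in a functional assay on HeLa cells (Homo sapiens) for cytotoxicity, read by MTT assay, with a stated time of 48 h; on this read-out higher numbers stand for weaker inhibition and lower numbers for stronger inhibition:

Compound 1 `Cc1ccc(S(=O)(=O)/N=C(/CCNC2=CC(=O)c3ccccc3C2=O)Nc2ccc(F)cc2)cc1`: 5890 nM
Compound 2 `Cc1ccc(S(=O)(=O)/N=C(/CCNC2=CC(=O)c3ccccc3C2=O)Nc2ccccc2[N+](=O)[O-])cc1`: 3310 nM
Compound 3 `COc1ccc(N/C(CCNC2=CC(=O)c3ccccc3C2=O)=N\S(=O)(=O)c2ccc(C)cc2)cc1OC`: 14500 nM

Compound 3 gives the highest number of the three. The steps to it, a 2.5-fold higher number from compound 1 to compound 3 (0.39 log units; beyond the scatter) and a 4.4-fold higher number from compound 2 to compound 3 (0.64 log units; beyond the scatter), are both beyond the scatter, so on these numbers compound 3 is the weakest inhibitor in this assay. Compound 1 and compound 2 lie within the scatter of each other, a 1.8-fold lower number from compound 1 to compound 2 (0.25 log units; within the scatter).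

Compound 4 `COc1cc(N/C(CCNC2=CC(=O)c3ccccc3C2=O)=N\S(=O)(=O)c2ccc(C)cc2)cc(OC)c1OC` differs from compound 3 by methoxy in place of hydrogen on an aromatic carbon. For the measured compounds named here, no measured pair shows a methoxy in place of hydrogen; the steps that exist all swap one whole aryl group for another, and the two that end at compound 3 each moved the number up. The change to compound 4 is a smaller one than any of them, and nothing here sets its direction. The expectation is therefore no step beyond the scatter, with compound 4 remaining near the weak end of the series: a 1.1-fold higher number from compound 3 to compound 4 (0.04 log units; within the scatter). Compound 4 is estimated at 16000 nM, in the range 7000 nM to 36000 nM.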

Compound 4, half-maximal inhibitory concentration: 3390 nM
For compound 4 the middle estimate is 4.7-fold (0.67 log units) above the measured one; the measured number lies below the stated range.
By their numbers in this assay, from the lowest: compounds 2, 4 and 1 (each within the scatter of the next); then compound 3.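

In this assay, for the compounds shown here, methoxy in place of hydrogen on an aromatic carbon, ortho to a methoxy group, is the first step that changes a single substituent rather than a whole aryl group, and it lies beyond the scatter (a 4.3-fold lower number from compound 3 to compound 4 (0.63 log units; beyond the scatter)). The 3,4,5-trimethoxyphenyl group does not stay with the 3,4-dimethoxyphenyl group at the high end: the other two steps (a 1.0-fold higher number from compound 2 to compound 4 (0.01 log units; within the scatter); a 1.7-fold lower number from compound 1 to compound 4 (0.24 log units; within the scatter)) are both within the scatter, so among the aryl groups shown, only 3,4-dimethoxyphenyl stands apart. Nothing measured here bears on the reason for this step.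

On these data alone, it remains open whether the step belongs to methoxy as such or to any group at this place on the ring. A hydroxyl or an amine in place of the added methoxy would separate these two readings.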